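Working notes: linker exchange from compound 2 to compound 3

The source may report more compounds than this note shows. Statements on the series, on what has been measured and on what is new or still open speak of the compounds shown alone.

Measured so far:
compound 1 `COc1ccc(CNc2nc3cc(N)cc(N)c3nc2-c2ccccc2)cc1OC` — 7940 nM
compound 2 `Nc1cc(N)c2nc(-c3ccccc3)c(NCc3ccc(F)cc3)nc2c1` — 2510 nM

In a functional assay on COLO 205 cells (Homo sapiens) for inhibition, read by sulforhodamine B assay, with a stated time of 48 h (on this read-out higher numbers stand for weaker inhibition of growth and lower numbers for stronger inhibition of growth), compound 2 gives 2510 nM, the lowest of the two numbers recorded. Among the measured compounds shown here, its nearest neighbour is compound 1, which in this assay gives 7940 nM; the step of a 3.2-fold lower number from compound 1 to compound 2 (0.50 log units; beyond the scatter) is the only comparison available and it exchanges one aryl group for another on the saturated chain carbon while the amine linker stays in place.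

Compound 3 `Nc1cc(N)c2nc(-c3ccccc3)c(Sc3ccc(F)cc3)nc2c1` is the next candidate. Relative to compound 2 the change is (4-fluorophenyl)sulfanyl in place of (4-fluorobenzyl)amino on an aromatic carbon. For the measured compounds named here, no measured pair touches the linker itself; the step of a 3.2-fold lower number from compound 1 to compound 2 (0.50 log units; beyond the scatter) speaks to the aryl substituent only and therefore gives no direct reading on replacing the benzylamino linker with a sulfanyl one. Going by the values given here, with no step that bears on it, the expectation in this assay for compound 3 is a number not far from that of compound 2, with a wide range to either side.

For compound 3 the estimate in this assay is 2500 nM, with a range from 600 nM to 10000 nM, which is expected to correspond to a 1.0-fold lower number from compound 2 to compound 3 (0.00 log units; within the scatter).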

Compound 3, concentration for 50% growth inhibition: 21900 nM
Beside the measured number, compound 3's estimate is 8.8-fold (0.94 log units) below it; the measured number lies above the stated range.
By their numbers in this assay, from the lowest: compound 2; then compound 1; then compound 3.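

In this assay, among the compounds shown here, exchanging (4-fluorobenzyl)amino for (4-fluorophenyl)sulfanyl on the aromatic carbon next to the ring nitrogen gives an 8.7-fold higher number from compound 2 to compound 3 (0.94 log units; beyond the scatter), the first reading on the linker at this position, since a 3.2-fold lower number from compound 1 to compound 2 (0.50 log units; beyond the scatter) changes only the aryl group and leaves the linker in place. This single step changes several features together: the linking nitrogen gives way to sulfur, the heavy atoms go from 9 to 8, and the hydrogen-bond donors go from 1 to 0, so the shift cannot be assigned to any one of them. No measurement at hand accounts for the higher number.

The compounds shown leave open whether the step follows from the change of linking atom or from the loss of the saturated chain carbon: a (4-fluorophenyl)amino group and a (4-fluorobenzyl)sulfanyl group would each separate these two changes. Also open, going by these compounds, is whether the aryl step carries over to the sulfanyl series, as with a (3,4-dimethoxyphenyl)sulfanyl group, and how an ether oxygen linker would read at this position.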